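The source may report more compounds than this note shows. Statements on the series, on what has been measured and on what is new or still open speak of the compounds shown alone.

Measured so far in a functional assay on SW480 cells (Homo sapiens) for cytotoxicity, read by MTT assay, with a stated time of 72 h; a higher number here means a weaker inhibitor, a lower number a stronger inhibitor:

- compound 1, `Cc1nnc(SCc2coc3ccc(Cl)cc3c2=O)s1`: 3200 nM
- compound 2, `Cc1cc(C)n2nc(SCc3nnc(SCc4cc(=O)c5ccccc5o4)n3-c3ccccc3)nc2n1`: a limit of the assay, not a number

In this assay compound 1 gives 3200 nM, and this is the only number shown. For compound 2 this assay reports only > 25000 nM, which is a limit of the assay rather than a measured number, so nothing can be said about the size of the gap between compound 1 and compound 2 (the limit of > 25000 nM in this assay, at which 1 of the 2 values shown sits). Within the data shown here, no step between measured compounds can be computed here.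

Compound 3, `Cc1nnc(SCc2coc3ccccc3c2=O)s1`, differs from compound 1 in one place: hydrogen in place of chloro on an aromatic carbon. Only one heavy atom leaves and nothing enters beyond a hydrogen atom, so the shared core stays intact. Among the measured compounds shown here, with no measured step to lean on, the step from compound 1 to compound 3 is expected to be small, in the direction of a weaker inhibitor, and it may well sit within the usual scatter of repeated measurements, as a 1.6-fold higher number from compound 1 to compound 3 (0.19 log units; within the scatter) shows. Compound 3 is therefore estimated at 5000 nM, with a plausible range from 2000 nM to 15000 nM.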

Compound 3, half-maximal inhibitory concentration: 1000 nM
Beside the measured number, compound 3's estimate is 5.0-fold (0.70 log units) above it; the whole stated range lies above it.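

Taking the chloro off this aromatic carbon and leaving a hydrogen in its place gives a 3.2-fold lower number from compound 1 to compound 3 (0.51 log units; beyond the scatter) in this assay, and since a lower number means a stronger inhibitor, the compound without the chloro is the stronger of the pair. Among these compounds, this is the first step that can be read at all, and it shows that this carbon, on the six-membered aromatic ring of carbon only, is a place where the loss of a single heavy atom moves the reading beyond the usual scatter, so the chloro is not needed for the activity seen here and the plain hydrogen serves better. Nothing measured among these compounds speaks to why the number moves in this direction.

Among the compounds shown here, a single pair gives only one step at one position, so it cannot show whether the trend would hold for other groups on the same carbon, such as a fluoro, a methoxy or an amine. It also leaves open whether the same change would act alike on a different shared core.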